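Hydroxy in place of cyano: a step expected to stay flat

The source may report more compounds than this note shows. Statements on the series, on what has been measured and on what is new or still open speak of the compounds shown alone.

Within the data shown here, compound 2 `N#Cc1ccc(-c2cc(-c3ccccc3)c3cc(Br)ccc3n2)cc1` gives 98800 nM in a functional assay on Hep2C cells (Homo sapiens) for antiproliferative activity, read by MTT assay, with a stated time of 24 h (a higher number here means a weaker inhibitor, a lower number a stronger inhibitor), the lower of the two numbers so far, though the gap to compound 1 `Brc1ccc2nc(-c3ccco3)cc(-c3ccccc3)c2c1`, which gives 102000 nM, is within the scatter. Compound 3 `Oc1ccc(-c2cc(-c3ccccc3)c3cc(Br)ccc3n2)cc1` differs from compound 2 by hydroxy in place of cyano on an aromatic carbon, a hydroxy in place of cyano on an aromatic carbon. Among the measured compounds shown here, the only measured step at that site, a 1.0-fold lower number from compound 1 to compound 2 (0.01 log units; within the scatter), stayed within the scatter, and it swapped a whole ring rather than one substituent, so it bears on this change only loosely. No step beyond the scatter is therefore expected. For compound 3 the estimate is 95000 nM, between 40000 nM and 250000 nM. That amounts to an expected 1.0-fold lower number from compound 2 to compound 3 (0.02 log units; within the scatter).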

Compound 3, half-maximal inhibitory concentration: 105000 nM
Beside the measured number, compound 3's estimate is 1.1-fold (0.04 log units) below it; measured number inside the range.
By their numbers in this assay, from the lowest: compounds 2, 1 and 3 (each within the scatter of the next).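

Hydroxy in place of cyano gives a 1.1-fold higher number from compound 2 to compound 3 (0.03 log units; within the scatter) in this assay and is the first change at this position that replaces a single substituent rather than a whole ring; it brings in a hydrogen-bond donor, and the number stays within the scatter. Set against furan-2-yl, 4-hydroxyphenyl gives a 1.0-fold higher number from compound 1 to compound 3 (0.01 log units; within the scatter) and so cannot be told apart from it in this assay either. No evidence is available that accounts for this flat result.

On these data alone, whether an amine or a carboxylic acid on this ring, para to the same large group, would move the number beyond the scatter stays open. The compounds shown therefore identify no change at this site that shifts the number in either direction.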